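The compounds below may be only part of what the source reports. "The series", "measured", "known", "first", "only" and "open" are said of these compounds alone.

Among the compounds with values here, compound 2 `CC(C)=CCC/C(C)=C/CC1Cc2c(OC(=O)Nc3cccc(F)c3)cc(=O)n(CCCO)c2CC1(C)C` is one of two compounds measured in a functional assay on PANC-1 cells (Homo sapiens) for inhibition, read by MTT assay, with a stated time of 24 h, tested at 10 uM (a lower number here means less inhibition, a higher number more inhibition at the concentration tested (going by the name of the read-out)), and in that assay compound 2 gives 0%. Within the data shown here, the only other number comes from compound 1 `CC(C)=CCC/C(C)=C/COc1cc(=O)n(CCCO)c2c1CC(C/C=C(\C)CCC=C(C)C)C(C)(C)C2`, which in this assay gives 3.1%. The step of a number 3.1 percentage points lower from compound 1 to compound 2 (within the scatter), in which (3-fluorophenyl)carbamoyl took the place of 3,7-dimethylocta-2,6-dien-1-yl on an oxygen on an aromatic ring, is within the scatter, so the two values cannot be ordered against each other and both sit near the bottom of the scale.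

Compound 3 `CC(C)=CCC/C(C)=C/CC1Cc2c(OC(=O)Nc3ccc(F)c(F)c3)cc(=O)n(CCCO)c2CC1(C)C` differs from compound 2 by fluoro in place of hydrogen on an aromatic carbon. Among the measured compounds shown here, no measured pair shows this change. For the measured compounds named here, the one measured step, a number 3.1 percentage points lower from compound 1 to compound 2 (within the scatter), concerned a far larger exchange and still produced nothing beyond the scatter, so the small addition of fluoro gives no ground to expect a larger effect here. Compound 3 is therefore expected to show a step of a number 3 percentage points higher from compound 2 to compound 3 (within the scatter), within the scatter. The estimate for compound 3 in this assay is 3%, with a range from -8% to 15%.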

Compound 3, a percentage reported as inhibition, at one concentration (the size of the read-out at that concentration, not a potency): 4.8%
The estimate for compound 3 lay 1.8 percentage points below the measured number; measured number inside the range.
By their numbers in this assay, from the lowest: compounds 2, 1 and 3 (each within the scatter of the next).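

In this assay, within the data shown here, the change from 3-fluorophenyl to 3,4-difluorophenyl gives the first direct reading at this position, a step of a number 4.8 percentage points higher from compound 2 to compound 3 (within the scatter): fluoro on this aromatic carbon, ortho to a fluoro group and para to a large group, cannot be told apart from hydrogen. A second carbamoyl also leaves the exchange on the oxygen unresolved, since (3,4-difluorophenyl)carbamoyl in place of 3,7-dimethylocta-2,6-dien-1-yl gives a step of a number 1.7 percentage points higher from compound 1 to compound 3 (within the scatter). No measurement on these compounds speaks to what lies behind these numbers.

Whether an amine or a carboxylic acid on this aromatic ring, in place of fluoro, would give a step beyond the scatter remains open, as all three compounds shown carry either fluoro there or no such ring at all. Also open, on these data alone, is whether a shorter chain or a hydroxyl-bearing chain in place of the 3,7-dimethylocta-2,6-dien-1-yl group on the core carbon, which all three compounds share, would separate any compound from these values.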